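Piperidinyl Amide Variant on the Saturated Ring Core

A few compounds are considered here, and "the series" means these few. Any claim that something is new, unique, unknown or untested is made for them only; others in the source may bear on it.

Measured compounds:
compound 1, `CN(C)C(=O)[C@H]1CCC[C@@H](c2cccc(-n3ncc(C(=O)O)c3C3CC3)c2)C1`: 1700 nM
compound 2, `O=C(O)c1cnn(-c2cccc(-c3cccc(C(=O)N4CCCCC4)c3F)c2)c1C1CC1`: 2300 nM
compound 3, `CN(C)C(=O)c1cccc(-c2cccc(-n3ncc(C(=O)O)c3C3CC3)c2)c1F`: 1300 nM

All three were tested in an assay on BEAS-2B cells for activation of nuclear factor erythroid 2-related factor 2 (Homo sapiens), read by MTT assay, with a stated time of 48 h; on this read-out lower numbers stand for an effect already at smaller amounts and higher numbers for an effect only at larger amounts of compound. Compound 3 and compound 2 differ in one place, (piperidin-1-yl in place of dimethylamino on a carbonyl carbon), and this gave a 1.8-fold higher number from compound 3 to compound 2 (0.25 log units; within the scatter). Compound 1 carries a different core than compound 3, and the difference between the two cores is not broken down here; the values of compound 1 and compound 3 lie within the usual scatter of each other.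

Compound 4, `O=C(O)c1cnn(-c2cccc([C@@H]3CCC[C@H](C(=O)N4CCCCC4)C3)c2)c1C1CC1`, has not yet been measured. It differs from compound 1 in one place, (piperidin-1-yl in place of dimethylamino on a carbonyl carbon). Among the measured compounds shown here, the carbonyl carbon in compound 1 sits on a saturated ring carbon, whereas in compound 3 it sits on an aromatic carbon, so this is the same kind of change as the one from compound 3 to compound 2, not the same change. Beside that earlier step, the expected step in this assay is a 1.6-fold higher number from compound 1 to compound 4 (0.22 log units; within the scatter), resting on a 1.8-fold higher number from compound 3 to compound 2 (0.25 log units; within the scatter). Compound 4 is thus estimated at 2800 nM, with a likely range from 1400 nM to 5600 nM.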

Compound 4, half-maximal effective concentration in the nuclear factor erythroid 2-related factor 2 assay: 2700 nM
Compound 4: middle estimate off by 1.0-fold (0.02 log units), on the high side, and the stated range covers the measured number.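

In the nuclear factor erythroid 2-related factor 2 assay, piperidin-1-yl in place of dimethylamino on the carbonyl carbon gave a 1.6-fold higher number from compound 1 to compound 4 (0.20 log units; within the scatter), and the change reads alike on the two cores: the same change on two cores in the nuclear factor erythroid 2-related factor 2 assay, a 1.8-fold higher number (0.25 log units; within the scatter) from compound 3 to compound 2 and a 1.6-fold higher number (0.20 log units; within the scatter) from compound 1 to compound 4, 1.1-fold (0.05 log units) apart, within the scatter of two such steps. Among the compounds shown here, each step is itself within the scatter, so this shows only that the swap leaves the read-out within ordinary repeat variation on both cores; it does not show that the swap has a real effect on this read-out, or that it would behave the same way on any further core. The same swap on the core of compound 1 does give a clear difference in lipophilicity, in a physicochemical assay for lipophilicity, read by HPLC, at pH 2; on this read-out higher numbers stand for higher lipophilicity and lower numbers for lower lipophilicity: the measured distribution coefficient of compound 1, 1.7, and of compound 4, 2.7, a number 1.00 log units higher (beyond the scatter). In the physicochemical assay compound 1 gives 1.7 and compound 4 gives 2.7.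

The compounds shown leave open how a longer chain such as diethylamino would read on the carbonyl carbon in place of these two groups. They also leave open what a hydroxyl group or an amine added to the piperidin-1-yl group would do on either core.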